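Compound 4: hydrogen in place of hydroxy

The compounds below may be only part of what the source reports. "The series", "measured", "known", "first", "only" and "open" are said of these compounds alone.

Measured in a functional assay on MCF7 cells (Homo sapiens) for cytotoxicity, read by MTT assay, with a stated time of 72 h (on this read-out higher numbers stand for weaker inhibition and lower numbers for stronger inhibition), so far
compound 1 `O=C1C(=Cc2ccc(F)cc2)C(=O)N(c2ccc(Cl)cc2)N1c1ccc(Cl)cc1` gives 31400 nM
compound 2 `COc1cc(C=C2C(=O)N(c3ccc(Cl)cc3)N(c3ccc(Cl)cc3)C2=O)cc(OC)c1OC` gives 16200 nM
compound 3 `COc1cc(C=C2C(=O)N(c3ccc(Cl)cc3)N(c3ccc(Cl)cc3)C2=O)ccc1O` gives 22800 nM

Compound 3 at 22800 nM sits among these three values and lies within the scatter of both compound 1 and compound 2, so no order can be read between it and either of them. Next is compound 4 `COc1cccc(C=C2C(=O)N(c3ccc(Cl)cc3)N(c3ccc(Cl)cc3)C2=O)c1` with hydrogen in place of hydroxy on an aromatic carbon, which turns 4-hydroxy-3-methoxyphenyl into 3-methoxyphenyl. The counted difference is hydrogen in place of hydroxy on an aromatic carbon and nothing else in the structure changes.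

For the measured compounds named here, only one measured step bears on this aryl group. That step is a 1.4-fold lower number from compound 1 to compound 3 (0.14 log units; within the scatter) and it brought in 4-hydroxy-3-methoxyphenyl in place of 4-fluorophenyl without leaving the scatter. Going by the values given here, no measured pair isolates the hydroxy group alone, so the data give no direction for its loss. The expectation in this assay is therefore no step beyond the scatter. The estimated step is a 1.0-fold higher number from compound 3 to compound 4 (0.00 log units; within the scatter) in either direction by chance alone. For compound 4 the expected value is 23000 nM with an estimated range from 11000 nM to 46000 nM as the working figure.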

Compound 4, half-maximal inhibitory concentration: 18100 nM
The estimate for compound 4 lay 1.3-fold (0.10 log units) above the measured number; the range from low to high includes it.
By their numbers in this assay, from the lowest: compounds 2, 4, 3 and 1 (each within the scatter of the next).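

In this assay, for the compounds shown here, removing the hydroxy group from the 4-hydroxy-3-methoxyphenyl group gives a 1.3-fold lower number from compound 3 to compound 4 (0.10 log units; within the scatter), and this is the first measured pair to isolate that group. At this place, ortho to a methoxy group, hydrogen and hydroxy therefore cannot be told apart on this read-out, and the hydroxy group shows no measurable contribution here. Replacing 4-fluorophenyl with 3-methoxyphenyl gives a 1.7-fold lower number from compound 1 to compound 4 (0.24 log units; within the scatter), so this aryl exchange also stays unresolved, and no data in hand bear on why these values lie so close together.

The compounds shown carry only fluoro, hydroxy and methoxy groups on this aryl ring, so it remains open whether an amine or a carboxylic acid in place of the hydroxy would produce a step beyond the scatter. The two chlorophenyl groups on the shared core stay the same in every compound shown, so the effect of a change there on this read-out is also open.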